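The compounds below may be only part of what the source reports. "The series", "measured", "known", "first", "only" and "open" are said of these compounds alone.

Measured so far in an ADME assay on L6 cells (Rattus norvegicus) for cytotoxicity; on this read-out higher numbers stand for weaker inhibition and lower numbers for stronger inhibition
compound 1 `N#Cc1ccccc1N1CCN(C(=O)Cn2cnc([N+](=O)[O-])n2)CC1` gives 213000 nM
compound 2 `N#Cc1ccccc1N1CCN(CC(=O)N2CCN(c3ccccc3C#N)CC2)CC1` gives 127000 nM
compound 3 `O=C(CN1CCN(c2ccc(Cl)c(Cl)c2)CC1)N1CCN(c2ccc(Cl)c(Cl)c2)CC1` gives 20200 nM

In this assay compound 1 stands level with compound 2, their two values lying within the scatter of each other. Compound 3 shows a lower number than compound 1, and that gap lies beyond the scatter.

The next compound to be tested, compound 4 `O=C(Cn1cnc([N+](=O)[O-])n1)N1CCN(c2ccccn2)CC1`, has pyridin-2-yl in place of 2-cyanophenyl on an amine nitrogen in a ring. For the measured compounds named here, no measured pair shows this change on its own, so the data offer only an indirect guide. Going by the values given here, compound 3 (20200 nM) is the one compound set apart from the others, and it carries chlorine on its aromatic rings, which compound 4 does not. Compound 4 keeps the nitro-bearing side of compound 1 (213000 nM) and changes only the aromatic group. In this assay no step beyond the scatter is therefore expected in either direction. The estimated step is small (a 1.2-fold lower number from compound 1 to compound 4 (0.07 log units; within the scatter)). Among the compounds with values here, compound 4 is expected to read about 180000 nM in this assay, with an estimated range from 70000 nM to 400000 nM (a wide range, as only three values support it).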

Compound 4, half-maximal inhibitory concentration: 173000 nM
The estimate for compound 4 lay 1.0-fold (0.02 log units) above the measured number; the range from low to high includes it.
By their numbers in this assay, from the lowest: compound 3; then compounds 2, 4 and 1 (each within the scatter of the next).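

In this assay, for the compounds shown here, the exchange of 2-cyanophenyl for pyridin-2-yl on an amine nitrogen in a ring gives the first step in this set that isolates a single place, a 1.2-fold lower number from compound 1 to compound 4 (0.09 log units; within the scatter). It shows that, at this position and with the nitro-bearing side kept, the read-out stays within the scatter when the nitrile leaves and the all-carbon aromatic ring gives way to a ring holding a hetero atom. No measurement offered here explains why this exchange leaves the number within the scatter.

This single exchange does not show whether another group at the same position, such as a phenyl ring carrying a carboxylic acid or an amine, would move the number beyond the scatter. Compound 3 differs from compound 1 and compound 4 in more than one place, so the compounds shown leave open whether chlorine on the aromatic ring, taken alone, would change the read-out on the nitro-bearing compounds.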